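The compounds below may be only part of what the source reports. "The series", "measured", "known", "first", "only" and "open" are said of these compounds alone.

Measured compounds:
Compound 1 `O=C(CCCc1ccccc1)Nc1nc2ccc(Cl)cc2c(=O)s1`: in an assay on CHO cells for displacement of a labelled ligand from adenosine receptor A2b (Homo sapiens), read by scintillation counting, with a stated time of 75 min (a higher number here means a weaker inhibitor, a lower number a stronger inhibitor), compound 1 reaches only the assay limit, > 1000 nM.
Compound 2 `O=C(CCCc1ccccc1)Nc1nc2ccccc2c(=O)s1`: in this assay compound 2 likewise reaches only the limit, > 1000 nM.
Compound 3 `O=C(C/C=C/c1ccccc1)Nc1nc2ccccc2c(=O)s1`: in this assay compound 3 gives 119 nM.

Compound 2 thus stands at the limit of this assay, a value the assay cannot read further, and this is the limit of > 1000 nM in this assay, at which 2 of the 3 values shown sit. From compound 2 to compound 4 `O=C(CCCc1cccc(Cl)c1)Nc1nc2ccccc2c(=O)s1` the change is chloro in place of hydrogen on an aromatic carbon. Within the data shown here, the only measured step, a step that the two limits leave unreadable from compound 1 to compound 2, concerns a chloro on the shared core and is unreadable, so no measured step bears on this change, and no shift beyond the scatter is expected in this assay. Compound 4 is therefore expected to sit near the limit as well, estimated at 1500 nM with a range of 500 nM to 5000 nM, meaning an expected step that the limit leaves unreadable from compound 2 to compound 4.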

Compound 4, inhibition constant: >= 1000 nM
Compound 4 was reported as a limit; the forecaster's own chance of this, stated with the estimate: 60%; the middle value does not contradict the limit.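

Compound 2 and compound 4 both sit at limits of this assay, so the step between them cannot be read. Left open is whether chloro in place of hydrogen on the phenyl ring shifts the inhibition constant at all.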